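Compound 3 and the 4-cyanophenyl change

The source may report more compounds than this note shows. Statements on the series, on what has been measured and on what is new or still open speak of the compounds shown alone.

All values below come from a functional assay on HCT-116 cells (Homo sapiens) for antiproliferative activity, read by MTT assay, with a stated time of 72 h (a lower number here means a stronger inhibitor, a higher number a weaker inhibitor), and stand as follows.

- Compound 1 (`CC(C)c1cccc(NC(=O)CCc2cccc3c2B(O)OC3)c1`) gives 1600 nM
- Compound 2 (`O=C(CCc1cccc2c1B(O)OC2)Nc1cccc(-c2ccc(F)cc2)c1`) gives 550 nM
- Compound 3 (`O=C(CCc1cccc2c1B(O)OC2)Nc1cccc(-c2cccc(C(F)(F)F)c2)c1`) gives 580 nM

Compound 3, at 580 nM in this assay, sits within the scatter of compound 2 and clear of compound 1. The next case is compound 4 (`N#Cc1ccc(-c2cccc(NC(=O)CCc3cccc4c3B(O)OC4)c2)cc1`), which carries 4-cyanophenyl in place of 3-(trifluoromethyl)phenyl on an aromatic carbon.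

Among the compounds with values here, three measured steps bear on this change. Within the data shown here, exchanging one substituted phenyl group for another moved the number very little, and the single example is a 1.1-fold higher number from compound 2 to compound 3 (0.02 log units; within the scatter). The modest shifts came on leaving isopropyl, in a 2.9-fold lower number from compound 1 to compound 2 (0.46 log units; beyond the scatter) and in a 2.8-fold lower number from compound 1 to compound 3 (0.44 log units; beyond the scatter). A substituted phenyl group remains in place here, so no step beyond the scatter is expected, and the estimate is a 1.1-fold lower number from compound 3 to compound 4 (0.02 log units; within the scatter). Compound 4 is expected at 550 nM, with an estimated range of 250 nM to 1200 nM.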

Compound 4, half-maximal inhibitory concentration: 410 nM
Beside the measured number, compound 4's estimate is 1.3-fold (0.13 log units) above it; low and high end bracket the measured number.
By their numbers in this assay, from the lowest: compounds 4, 2 and 3 (each within the scatter of the next); then compound 1.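

In this assay, 4-cyanophenyl at this position gives a 1.4-fold lower number from compound 3 to compound 4 (0.15 log units; within the scatter) and a 1.3-fold lower number from compound 2 to compound 4 (0.13 log units; within the scatter), so a nitrile on the added ring, with its hydrogen-bond acceptor, leaves compound 4 level with both earlier substituted phenyl compounds. Against isopropyl, the change gives a 3.9-fold lower number from compound 1 to compound 4 (0.59 log units; beyond the scatter) and stands as a third step beyond the scatter, so compounds 2, 3 and 4 all part from compound 1 with three different substituted phenyl groups. No measurement available here accounts for this result.

On these data alone, whether an amine or a carboxylic acid on the added phenyl group would keep the number in this range remains open. So does the reading for an unsubstituted phenyl group or a saturated ring such as cyclohexyl at this position.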